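The compounds below may be only part of what the source reports. "The series", "measured", "known", "first", "only" and "open" are said of these compounds alone.

Measured compounds:
- Compound 1, `O=S(=O)(Nc1ccc(-c2nc3ccccc3o2)cc1)c1ccc(F)c(C(F)(F)F)c1`: 28000 nM
- Compound 2, `O=S(=O)(Nc1ccc(-c2nc3ccccc3o2)cc1)c1cccc(Cl)c1`: 54000 nM
- Compound 3, `O=S(=O)(Nc1ccc2oc(-c3ccccc3)nc2c1)c1ccc(Cl)c(C(F)(F)F)c1`: > 100000 nM

In an assay on cells for inhibition of HSP60/HSP10 (Homo sapiens), with a stated time of 60 min (a higher number here means a weaker inhibitor, a lower number a stronger inhibitor), compound 1 gives 28000 nM and compound 2 gives 54000 nM; these two numbers sit within the usual scatter of each other, so nothing can be said about which of the two is the stronger inhibitor. Compound 3 is different in that its shared core carries the sulfonamide at another point, and in this assay compound 3 reaches only a limit, > 100000 nM, which is the assay's boundary rather than a number (the limit of > 100000 nM in this assay, at which 1 of the 3 values shown sits). Among the two actual numbers, compound 2 stands at the higher one, with compound 1 close by.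

The step now followed leads from compound 2 to compound 4, `CCc1ccc(S(=O)(=O)Nc2ccc(-c3nc4ccccc4o3)cc2)cc1`, which is not yet measured in this assay. The change is 4-ethylphenyl in place of 3-chlorophenyl on a sulfonyl sulfur. Among the measured compounds shown here, no measured pair here shows what such a change does, so the expectation must rest on compound 2 alone.

Given that compound 2 gives 54000 nM, the step from compound 2 to compound 4 is expected to be a 1.1-fold lower number from compound 2 to compound 4 (0.03 log units; within the scatter), that is, no change beyond the scatter in either direction. Compound 4 is therefore estimated at 50000 nM, with a likely range from 15000 nM to 150000 nM.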

Compound 4, half-maximal inhibitory concentration: > 100000 nM
Compound 4: a limit, no number; the forecaster's own chance of this, stated with the estimate: 30%; at least 2.0-fold (0.30 log units) between middle value and limit.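

In this assay compound 4 gives > 100000 nM, which is a limit of the assay and not a number. Placing 4-ethylphenyl in place of 3-chlorophenyl on a sulfonyl sulfur gives an at least 1.8-fold higher number from compound 2 to compound 4 (0.26 log units; that floor lies within the scatter), so this change may be small or much larger, and the data cannot show which. Compound 4 is also the first compound with the sulfonamide attached as in compounds 1 and 2 whose ring on the sulfonyl sulfur carries no halogen, and it shows that the limit is not confined to compound 3, which has the sulfonamide at another point on the shared core: the limit of > 100000 nM in this assay, at which 2 of the 4 values shown sit.

3-Chlorophenyl and 4-ethylphenyl differ both in the group carried and in its place on the ring, and the compounds shown do not separate these two parts of the change. Also open, from the compounds shown here alone, is how this position would respond to an amine or a carboxylic acid on the same ring, since every ring here bears only halogen-containing groups or ethyl.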